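Swapping Pyridin-2-yl for 2-Methoxyphenyl on a Shared Core

The compounds below may be only part of what the source reports. "The series", "measured", "known", "first", "only" and "open" are said of these compounds alone.

Measured so far:
Compound 1 `Cc1cc2nn(-c3ccccc3)c(N)c2c(=O)[nH]1`: 1%
Compound 2 `Nc1c2c(=O)[nH]c(-c3ccccn3)cc2nn1-c1ccccc1`: 8%

Both were tested in an assay on isolated protein for inhibition of RAC-beta serine/threonine-protein kinase (Homo sapiens), read by mobility shift assay, tested at 30 uM; on this read-out lower numbers stand for less inhibition and higher numbers for more inhibition at the one concentration tested (going by the name of the read-out). On the numbers shown, compound 2 stands at the higher of the two, with compound 1 as its only neighbour, yet the step of a number 7 percentage points higher from compound 1 to compound 2 (within the scatter) lies within the scatter, so the two compounds cannot really be told apart.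

Compound 3 `COc1ccccc1-c1cc2nn(-c3ccccc3)c(N)c2c(=O)[nH]1` is the next member. The change from compound 2 is 2-methoxyphenyl in place of pyridin-2-yl on an aromatic carbon. Among the measured compounds shown here, the only measured step, from compound 1 to compound 2, traded a methyl for an aromatic ring at this same place and moved the number only within the scatter; no measured step trades one aromatic ring for another. The expectation for compound 3 is therefore a step of no change at the digits printed from compound 2 to compound 3 (within the scatter), meaning nothing beyond the scatter. Compound 3 is estimated at 8%, within a range from 0% to 25%.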

Compound 3, a percentage reported as inhibition, at one concentration (the size of the read-out at that concentration, not a potency): 0%
For compound 3 the middle estimate is 8 percentage points above the measured one, and the stated range covers the measured number.
By their numbers in this assay, from the lowest: compounds 3, 1 and 2 (each within the scatter of the next).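

In this assay, the step is a number 8 percentage points lower from compound 2 to compound 3 (within the scatter), and replacing the methyl gives a number 1 percentage points lower from compound 1 to compound 3 (within the scatter). Among the compounds shown here, this is the first trade of one aromatic ring for another at this aromatic carbon, a carbon-only ring with a methoxy group for a ring containing nitrogen, and the methyl, pyridin-2-yl and 2-methoxyphenyl compounds still cannot be told apart at the one concentration tested. Nothing measured alongside these numbers speaks to what lies behind them.

Going by these compounds, it remains open whether any group at this place can move the number beyond the scatter, such as an amine, a carboxylic acid or a longer chain. On these data alone, it is also open whether a change elsewhere on the shared core would matter more than one at this position.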